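From Cyclohexyl to 3,5-Dichlorophenyl on a Shared Core

The source may hold more compounds than are shown below. What is called first, only, known or untested is meant among the compounds shown, and "the series" means these compounds.

Measured in a functional assay on BXPC-3 cells (Homo sapiens) for cytotoxicity, read by MTT assay, with a stated time of 72 h; on this read-out lower numbers stand for stronger inhibition and higher numbers for weaker inhibition:
compound 1 `CN1CCN(c2ccc(NC3=CC(=O)c4ncncc4C3=O)cc2)CC1` gives 900 nM
compound 2 `O=C1C(Nc2ccc(C3CCCCC3)cc2)=CC(=O)c2ncncc21` gives 500 nM
compound 3 `CC1=C(Nc2ccc(N3CCN(C)CC3)cc2)C(=O)c2cncnc2C1=O` gives 870 nM

Compound 2, at 500 nM, stands within the usual scatter of both other compounds, so these numbers set no order among the three. The next compound, compound 4 `O=C1C(Nc2ccc(-c3cc(Cl)cc(Cl)c3)cc2)=CC(=O)c2ncncc21`, keeps the core of compound 2 and exchanges a single group, with 3,5-dichlorophenyl in place of cyclohexyl on an aromatic carbon.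

Among the compounds with values here, no measured compound carries the incoming group, so the evidence is only indirect. The closest comparison is another exchange on an aromatic carbon, cyclohexyl in place of 4-methylpiperazin-1-yl, which gave a 1.8-fold lower number from compound 1 to compound 2 (0.26 log units; within the scatter). Methyl in place of hydrogen on a double-bonded ring carbon is a different kind of change, and it gave a 1.0-fold lower number from compound 1 to compound 3 (0.01 log units; within the scatter). Neither step rose above the scatter, and two steps are a thin basis for any trend. No step beyond the scatter is therefore expected in this assay, and the data favour no clear direction. The estimated step is a 1.1-fold lower number from compound 2 to compound 4 (0.05 log units; within the scatter). For compound 4 the expected value is 450 nM, with an estimated range from 150 nM to 1300 nM.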

Compound 4, half-maximal inhibitory concentration: 3300 nM
Compound 4: middle estimate off by 7.3-fold (0.87 log units), on the low side; measured number above the stated range.
By their numbers in this assay, from the lowest: compounds 2, 3 and 1 (each within the scatter of the next); then compound 4.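

In this assay, within the data shown here, this aromatic carbon, para to a large group, proves sensitive to what it carries: 3,5-dichlorophenyl in place of cyclohexyl gives a 6.6-fold higher number from compound 2 to compound 4 (0.82 log units; beyond the scatter), the first step at this place to go beyond the usual scatter. The same group in place of 4-methylpiperazin-1-yl gives a 3.7-fold higher number from compound 1 to compound 4 (0.56 log units; beyond the scatter), so both steps rise in the same direction, whereas cyclohexyl and 4-methylpiperazin-1-yl could not be told apart at this place. The exchange from compound 2 to compound 4 turns a non-aromatic ring into an aromatic one and also brings in two chlorine atoms, and no measurement here explains why the number rises.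

The compounds shown cannot separate the aromatic ring from the chlorine atoms, so a plain phenyl or a phenyl with a single chlorine would be the telling groups at this place, and an open-chain amine would test a different kind of group there. Also open, on these data alone, is whether the methyl on the double-bonded ring carbon, which gave no step beyond the scatter on the core of compound 1, would act the same way alongside 3,5-dichlorophenyl.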